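The compounds below may be only part of what the source reports. "The series", "measured", "known", "first", "only" and "open" are said of these compounds alone.

Measured compounds:
compound 1, `Nc1sc(-c2ccc(Cl)cc2)c(-c2ccc(Cl)cc2)c1C(=O)NC1CC1`: in a functional assay on A549 cells (Homo sapiens) for cytotoxicity, read by sulforhodamine B assay, with a stated time of 72 h (on this read-out lower numbers stand for stronger inhibition and higher numbers for weaker inhibition), compound 1 gives 1950 nM.
compound 2, `Nc1sc(-c2ccc(Cl)cc2)c(-c2ccc(Cl)cc2)c1C(=O)NC1CCCCC1`: in this assay compound 2 gives 2410 nM.
compound 3, `Nc1sc(-c2ccc([N+](=O)[O-])cc2)c(-c2ccc(Cl)cc2)c1C(=O)NC1CC1`: in this assay compound 3 is reported as "not determined" (no result reported), so no number is available for it.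

Compound 4 is `Nc1sc(-c2ccc([N+](=O)[O-])cc2)c(-c2ccc(Cl)cc2)c1C(=O)NC1CCCCC1` and is not yet measured. The core of compound 3 differs from the core of compound 1 by nitro in place of chloro on an aromatic carbon. Within the first pair the change cyclohexyl in place of cyclopropyl on an amide-type nitrogen gives a 1.2-fold higher number from compound 1 to compound 2 (0.09 log units; within the scatter). The same change is made from compound 3 to compound 4, (cyclohexyl in place of cyclopropyl on an amide-type nitrogen); the place is worded identically in both pairs, so this is the same change. Compound 3 has no number, so the new step cannot be sized from a measured point. The expectation for compound 4 rests on compound 1 at 1950 nM and compound 2 at 2410 nM, together with the step of a 1.2-fold higher number from compound 1 to compound 2 (0.09 log units; within the scatter) lying within scatter. Compound 4 is expected near 2600 nM, estimated between 800 nM and 9000 nM. The margins are wide; the core bearing nitro has no measured anchor.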

Compound 4, half-maximal inhibitory concentration: 15000 nM
The estimate for compound 4 lay 5.8-fold (0.76 log units) below the measured number, outside the stated range (above it).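

In this assay, nitro in place of chloro on an aromatic carbon gives a 6.2-fold higher number from compound 2 to compound 4 (0.79 log units; beyond the scatter), so with cyclohexyl on the amide-type nitrogen, the nitro core reads as the weaker inhibitor. Going by these compounds, the step from cyclopropyl to cyclohexyl on the nitro core cannot be read: compound 3 has no number, so it remains unknown whether that change carries over from the core of compound 1, or whether the nitro step would be the same size with cyclopropyl on that nitrogen. Nothing at hand accounts for the higher number.

Still open, on these data alone, is how an amine or a carboxylic acid in place of the nitro would read. Also open, as far as these compounds go, is how a longer chain would read in place of the cyclohexyl on the amide-type nitrogen.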